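Moving the methoxy group: from compound 1 to compound 4

The compounds below may be only part of what the source reports. "The series", "measured", "known", "first", "only" and "open" are said of these compounds alone.

Measured compounds in a functional assay on HT-29 cells (Homo sapiens) for inhibition, read by MTT assay, with a stated time of 72 h; on this read-out lower numbers stand for stronger inhibition of growth and higher numbers for weaker inhibition of growth:
compound 1 `COc1cccc(CNCCCNS(=O)(=O)c2cc(C(F)(F)F)cc(C(F)(F)F)c2)c1` gives 10000 nM
compound 2 `O=S(=O)(NCCCNCc1cccc(Cl)c1)c1cc(C(F)(F)F)cc(C(F)(F)F)c1` gives 14000 nM
compound 3 `O=S(=O)(NCCCNCc1ccc(Br)cc1)c1cc(C(F)(F)F)cc(C(F)(F)F)c1` gives 2200 nM

Compound 1 stands second highest of these three numbers. Its nearest neighbour is compound 2, with a 1.4-fold higher number from compound 1 to compound 2 (0.15 log units; within the scatter), a step within the scatter; its furthest is compound 3, with a 4.5-fold lower number from compound 1 to compound 3 (0.66 log units; beyond the scatter).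

Compound 4 `COc1ccc(CNCCCNS(=O)(=O)c2cc(C(F)(F)F)cc(C(F)(F)F)c2)cc1` has not yet been measured in this assay. It differs from compound 1 in one place: 4-methoxyphenyl in place of 3-methoxyphenyl on a saturated chain carbon bound to an amine nitrogen. Among the compounds with values here, no measured step moves a methoxy group alone. The two steps that bear on the change both bring a 4-bromophenyl onto the saturated chain carbon bound to the amine nitrogen, and both gave modestly lower numbers; the second is a 6.4-fold lower number from compound 2 to compound 3 (0.80 log units; beyond the scatter). Each of these, however, also exchanges one substituent for another. The data do not separate the part of the change that comes from position alone. A modest step toward a lower number is therefore expected, smaller than those two steps: the expected step is a 2.0-fold lower number from compound 1 to compound 4 (0.30 log units; within the scatter). Compound 4 is estimated at 5000 nM, within a range of 1500 nM to 15000 nM.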

Compound 4, concentration for 50% growth inhibition: 2900 nM
For compound 4 the middle estimate is 1.7-fold (0.24 log units) above the measured one; measured number inside the range.
By their numbers in this assay, from the lowest: compounds 3 and 4 (each within the scatter of the next); then compounds 1 and 2 (each within the scatter of the next).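

In this assay, within the data shown here, exchanging 3-methoxyphenyl for 4-methoxyphenyl changes only where the methoxy group sits, yet it gives a step beyond the scatter (a 3.4-fold lower number from compound 1 to compound 4 (0.54 log units; beyond the scatter)), so position alone matters here, which the earlier steps could not separate from the exchange of one substituent for another. The 4-methoxyphenyl and 4-bromophenyl compounds cannot be told apart (a 1.3-fold higher number from compound 3 to compound 4 (0.12 log units; within the scatter)), while the step from the 3-chlorophenyl compound is beyond the scatter (a 4.8-fold lower number from compound 2 to compound 4 (0.68 log units; beyond the scatter)), so among these four compounds both 4-substituted rings give lower numbers than both 3-substituted rings, with none against this. Nothing available explains this effect of position.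

As far as these compounds go, it remains open whether the pattern holds for one halogen alone, as a 4-chlorophenyl or a 3-bromophenyl group would show. A 2-methoxyphenyl group and a longer chain on the same core are also untested among the compounds shown.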